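This account rests on a few compounds, and the source may have more. Where it says the series, first, only, none or still open, it means among the compounds named here.

Of the compounds shown here, three of one shared core have been measured in a physicochemical assay for solubility, in phosphate buffer, with a stated time of 18 h, at pH 7.4; a higher number here means a more soluble compound, a lower number a less soluble compound. Compound 1 `COCCOc1cc2ncnc(-n3nc(-c4ccccn4)nc3N)c2cc1OCCOC` gives 30000 nM, compound 2 `COc1cc2nc(-c3ccccc3)nc(-n3nc(-c4ccccn4)nc3N)c2cc1OC` gives 2000 nM, and compound 3 `COCCOc1cc2c(-n3nc(-c4ccccn4)nc3N)ncnc2cc1OC` gives 8000 nM. Compound 3 thus stands second of the three: the step of a 3.8-fold lower number from compound 1 to compound 3 (0.57 log units; beyond the scatter) separates it from compound 1, while compound 2 sits further from it, on the lower side, by more than the usual scatter.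

Compound 4 `COc1cc2ncnc(-n3nc(-c4ccccn4)nc3N)c2cc1OCCCNC(=O)OCC(C)(C)C` differs from compound 3 at one place, (((neopentyloxycarbonyl)amino)methyl in place of methoxy on a saturated chain carbon, two bonds along the chain from an oxygen on an aromatic ring). Among the compounds with values here, only one measured step bears on this, and only loosely: in a 3.8-fold lower number from compound 1 to compound 3 (0.57 log units; beyond the scatter) a methoxymethyl was replaced by hydrogen on a saturated chain carbon bound to an oxygen on an aromatic ring, a shortening of the chain, whereas here the chain grows and a carbamate with a neopentyl group enters. That single step cannot be read directly onto a group of this kind. He therefore expects a modest step of a 1.6-fold lower number from compound 3 to compound 4 (0.20 log units; within the scatter), most likely downward, and estimates for compound 4 a value of 5000 nM, within 1500 nM to 20000 nM.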

Compound 4, solubility: 200 nM
The estimate for compound 4 lay 25-fold (1.40 log units) above the measured number; measured number below the stated range.
By their numbers in this assay, from the lowest: compound 4; then compound 2; then compound 3; then compound 1.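

Within the data shown here, at this position, on a saturated chain carbon, two bonds along the chain from an oxygen on an aromatic ring, the number in this assay moves much further than the earlier compounds showed: replacing methoxy with ((neopentyloxycarbonyl)amino)methyl gives a 40-fold lower number from compound 3 to compound 4 (1.60 log units; beyond the scatter) and is a larger step than the modest 3.8-fold lower number from compound 1 to compound 3 (0.57 log units; beyond the scatter) at the neighbouring chain carbon. The change extends the chain and brings in the carbamate together, so this single step does not separate the two. Nothing measured here gives a reason for the size of this step.

The compounds shown leave open how much of the step follows the neopentyl carbamate and how much the longer chain. They also leave open where a 3-aminopropyl group or a carboxylic acid at the end of the chain would fall in this assay on the same core.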